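The source may report more compounds than this note shows. Statements on the series, on what has been measured and on what is new or still open speak of the compounds shown alone.

Of the compounds shown here, two sharing one core have been tested in a functional assay on spleen for antagonist activity at Alpha-1B adrenergic receptor (Rattus norvegicus); on this read-out lower numbers stand for lower potency and higher numbers for higher potency (the scale is a negative logarithm). Compound 1 `COc1cccc(OC)c1OCCNCCOc1ccccc1OCc1ccc(Cl)cc1` gives 8.06 in this assay. Compound 2 `COc1cccc(OC)c1OCCNCCOc1ccccc1OCc1cccc([N+](=O)[O-])c1` gives 8.74. Among the measured compounds shown here, of these two numbers compound 1 stands lowest; the only measured neighbour is compound 2, and the step of a number 0.68 log units higher from compound 1 to compound 2 (beyond the scatter) tells how far apart the two lie. Compound 3 `COc1ccc(COc2ccccc2OCCNCCOc2c(OC)cccc2OC)cc1` has not yet been measured. It differs from compound 1 in a single place: methoxy in place of chloro on an aromatic carbon. For the measured compounds named here, the one measured step, a number 0.68 log units higher from compound 1 to compound 2 (beyond the scatter), swaps in a different group, a 3-nitrophenyl rather than a 4-methoxyphenyl, so it bears only loosely on the present change. It shows that exchanging the group at this end of the molecule can shift the number by a modest amount, but it offers no guide to the direction a methoxy group would take. Lacking a closer comparison, the expected step of a number 0.04 log units higher from compound 1 to compound 3 (within the scatter) is one that stays within the scatter. Compound 3 is therefore estimated at 8.1, with a range from 7.5 to 8.7.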

Compound 3, negative logarithm of the antagonist equilibrium constant: 9.51
For compound 3 the middle estimate is 1.41 log units below the measured one; measured number outside the range, above it.
By their numbers in this assay, from the lowest: compound 1; then compound 2; then compound 3.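

Swapping chloro for methoxy on this aromatic carbon, para to a large group, gives a number 1.45 log units higher from compound 1 to compound 3 (beyond the scatter) in this assay. This exchange of one heavy atom for two at the same end of the molecule produces a large step, whereas the earlier step was modest, so this single carbon can carry far more of the potency than compounds 1 and 2 alone suggested. The 4-methoxyphenyl group also outdoes the 3-nitrophenyl group, with a number 0.77 log units higher from compound 2 to compound 3 (beyond the scatter), which makes compound 3 the most potent of the three, as its steps to both others lie beyond the scatter, but no measurement here explains why methoxy has this effect.

Still open, going by these compounds, is whether the gain depends on the oxygen of the methoxy group, a question that a methyl or a hydroxy group on the same carbon would help to answer. The compounds shown also leave open how much depends on where the methoxy group sits on this ring, and whether an ethoxy group would go further still.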